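The source may hold more compounds than are shown below. What is called first, only, known or untested is meant among the compounds shown, and "the series" means these compounds.

Measured compounds

Compound 1 `O=S(=O)(Nc1ccc(-c2nc3ccccc3o2)cc1)c1cccs1`: in an assay on cells for inhibition of HSP60/HSP10 (Homo sapiens), with a stated time of 60 min (on this read-out higher numbers stand for weaker inhibition and lower numbers for stronger inhibition), compound 1 gives 63000 nM.
Compound 2 `Cc1ccccc1S(=O)(=O)Nc1ccc(-c2nc3ccccc3o2)cc1`: in this assay compound 2 gives 85000 nM.
Compound 3 `CS(=O)(=O)Nc1ccc(-c2nc3ccccc3o2)cc1`: in this assay compound 3 gives > 100000 nM, which is a limit of the assay and not a number.

All three share one core and differ only in the group carried on the sulfonyl sulfur. Compound 3, with methyl there, stands at the limit of > 100000 nM in this assay, at which 1 of the 3 values shown sits, so only a floor is known for it. The steps of an at least 1.5-fold higher number from compound 1 to compound 3 (0.20 log units; that floor lies within the scatter) and an at least 1.1-fold higher number from compound 2 to compound 3 (0.07 log units; that floor lies within the scatter) both run onto that floor and stay within the scatter, and a 1.3-fold higher number from compound 1 to compound 2 (0.13 log units; within the scatter) is within the scatter as well; the three measured compounds therefore cannot be put in any order against each other.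

Compound 4 `O=S(=O)(Nc1ccc(-c2nc3ccccc3o2)cc1)c1ccc(F)cc1` has not yet been measured. Against compound 3 the difference is 4-fluorophenyl in place of methyl on a sulfonyl sulfur. This step reverses the sense of the two measured steps onto compound 3, each of which replaced a ring on the sulfonyl sulfur with methyl. Both of those were small, so no more than a small move is expected here, if anything a slightly lower number, placing compound 4 near where compound 1 and compound 2 sit. The expected step is an at least 1.4-fold lower number from compound 3 to compound 4 (0.15 log units; that floor lies within the scatter). In this assay compound 4 is estimated at 70000 nM, with a range from 30000 nM to 160000 nM.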

Compound 4, half-maximal inhibitory concentration: 73000 nM
Beside the measured number, compound 4's estimate is 1.0-fold (0.02 log units) below it, and the stated range covers the measured number.
By their numbers in this assay, from the lowest: compounds 1, 4 and 2 (each within the scatter of the next). At a limit, above all of these: compound 3.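

In this assay the step to 4-fluorophenyl adds a third ring on the sulfonyl sulfur, and a 1.2-fold lower number from compound 2 to compound 4 (0.07 log units; within the scatter) and a 1.2-fold higher number from compound 1 to compound 4 (0.06 log units; within the scatter) both lie within the scatter, so 4-fluorophenyl, 2-methylphenyl and thiophen-2-yl cannot be told apart at this position. The result also shows that a fluorine-bearing six-membered aromatic ring gives no separation from the rings already there, and the reading an at least 1.3-fold lower number from compound 3 to compound 4 (0.13 log units; that floor lies within the scatter) stays within the scatter as well, so a ring in place of methyl is still not shown to change the number. For compound 3 only a limit of the assay is known, so the step onto it remains a floor: the limit of > 100000 nM in this assay, at which 1 of the 4 values shown sits.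

Going by these compounds, what remains open is whether any group on the sulfonyl sulfur can move the number beyond the scatter, for example an amine or a carboxylic acid carried on the phenyl ring, or a longer chain in place of methyl. The compounds shown also leave open whether a change elsewhere on the shared core would do more than the changes at this position, since all of them differ only in the group on the sulfonyl sulfur.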